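The compounds below may be only part of what the source reports. "The series", "measured", "known", "first", "only" and "open" are said of these compounds alone.

Measured compounds in a functional assay on Bel-7402 cells (Homo sapiens) for inhibition, read by sulforhodamine B assay, with a stated time of 72 h, tested at 10 uM; a higher number here means more inhibition at the concentration tested (going by the name of the read-out), a lower number less inhibition:

compound 1, `C[C@H](Nc1ncnc2[nH]cnc12)c1nn(-c2cccnc2)c2cc(F)ccc12`: 8%
compound 2, `CC[C@H](Nc1ncnc2[nH]cnc12)c1nn(-c2cccnc2)c2cc(F)ccc12`: 12%

Among the compounds with values here, only two compounds have been measured, and they share one core; they differ only in the chain that carries the amine. Compound 2 carries an ethyl group where compound 1 carries a methyl group, and the step of a number 4 percentage points higher from compound 1 to compound 2 (within the scatter) lies within the usual scatter of repeated measurements, so the two numbers cannot be told apart. Compound 2 therefore stands level with compound 1 rather than above it.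

Compound 3, `CC(C)[C@H](Nc1ncnc2[nH]cnc12)c1nn(-c2cccnc2)c2cc(F)ccc12`, is not yet measured. It differs from compound 2 by methyl in place of hydrogen on a saturated chain carbon bound to two saturated chain carbons. Within the data shown here, this is the same kind of change as the one between compound 1 and compound 2, a chain made one carbon larger, and that earlier change produced no step beyond the scatter. On this basis the step of no change at the digits printed from compound 2 to compound 3 (within the scatter) is expected to stay within the scatter in this assay, with no clear direction. Compound 3 is estimated at 12%, in a range from 0% to 26%.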

Compound 3, a percentage reported as inhibition, at one concentration (the size of the read-out at that concentration, not a potency): 5%
Compound 3: the middle estimate sits 7 percentage points above what was measured; the measured number falls inside the stated range.
By their numbers in this assay, from the lowest: compounds 3, 1 and 2 (each within the scatter of the next).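

In this assay, the change from ethyl to isopropyl on the saturated chain carbon gives a number 7 percentage points lower from compound 2 to compound 3 (within the scatter), and putting isopropyl in place of methyl, the largest change in this set, gives a number 3 percentage points lower from compound 1 to compound 3 (within the scatter). Methyl, ethyl and isopropyl now form a series of three at this position, and neither a single added carbon nor the full change from methyl to isopropyl separates any two of them, so the new branch shows no readable effect in either direction. No outside data are available to explain these numbers.

On these data alone, it remains open whether a different kind of group at this position, such as a longer chain like n-butyl, a cyclopropyl ring, or a chain ending in an amine or a carboxylic acid, would move the number beyond the scatter. As far as these compounds go, it is also open whether these three chains would separate at other concentrations, as a reading at one concentration shows the size of the effect there and not a potency.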